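The compounds below may be only part of what the source reports. "The series", "measured", "known", "first", "only" and "open" are said of these compounds alone.

Of the compounds shown here, three built on a shared core have been tested in an assay on HEK293 cells for inhibition of transient receptor potential cation channel subfamily V member 6 (Homo sapiens), read by FLIPR and calcium flux, with a stated time of 5 min; a higher number here means a weaker inhibitor, a lower number a stronger inhibitor. Compound 1 `Fc1ccc([B-]2(c3ccc(F)cc3)[NH2+]CCO2)cc1` gives 17000 nM in this assay. Compound 2 `Fc1ccc([B-]2(c3ccccc3)[NH2+]CCO2)cc1` gives 18800 nM in this assay, and compound 3 `Cc1ccccc1[B-]1(c2ccccc2)[NH2+]CCO1` gives 31100 nM in this assay. Among these three numbers compound 2 stands second highest; its nearest neighbour is compound 1 and its furthest is compound 3, and both gaps lie within the scatter, so no order among the three can be read from them.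

One step joins two measured compounds that differ in a single place: hydrogen in place of fluoro on an aromatic carbon, which gave a 1.1-fold higher number from compound 1 to compound 2 (0.04 log units; within the scatter).

The new compound, compound 4 `Ic1ccc([B-]2(c3ccccc3)[NH2+]CCO2)cc1`, differs from compound 2 by iodo in place of fluoro on an aromatic carbon. Going by the values given here, the only measured step that bears on this is the one from compound 1 to compound 2, which also exchanges the group on an aromatic carbon and stayed within the scatter. Among the compounds with values here, no measured step covers iodo entering for fluoro. The expectation in this assay is therefore a step within the scatter, in no particular direction. Compound 4 is estimated at 17000 nM, with a range from 6000 nM to 50000 nM. This estimate amounts to an expected 1.1-fold lower number from compound 2 to compound 4 (0.04 log units; within the scatter).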

Compound 4, half-maximal inhibitory concentration: 5400 nM
The estimate for compound 4 lay 3.1-fold (0.50 log units) above the measured number, and the stated range ends above it.
By their numbers in this assay, from the lowest: compound 4; then compounds 1, 2 and 3 (each within the scatter of the next).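

The place on the aromatic ring para to a large group is not indifferent to what sits on it: in this assay, iodo in place of fluoro gives a 3.5-fold lower number from compound 2 to compound 4 (0.54 log units; beyond the scatter), a modest step but one beyond the scatter. The earlier exchange on an aromatic carbon, hydrogen in place of fluoro, gave a 1.1-fold higher number from compound 1 to compound 2 (0.04 log units; within the scatter) and stayed within the scatter, so it gave no sign that a single atom changed here could shift the number at all. The data shown offer no measurement that explains why iodo and fluoro differ at this place.

With only two such groups compared directly, the compounds shown cannot tell where chloro or bromo would fall at this same place, so no trend can be drawn from this one step. They also leave open whether an amine, a carboxylic acid or a methoxy group at this place would lower the number further or raise it, and whether iodo would give a similar step on the second aromatic ring.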